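Chain lengthening on the shared core, one place at a time

The compounds below may be only part of what the source reports. "The series", "measured", "known", "first", "only" and "open" are said of these compounds alone.

Compound 1 `Cc1ccc(NC(=O)N[C@H](C)c2ccccc2)cc1` and compound 2 `CCCCc1ccc(NC(=O)N[C@H](C)c2ccccc2)cc1` share one core and differ in a single place. In an ADME assay on the whole organism with Oryza sativa as the target, tested at 1 uM (a higher number here means a weaker effect of the compound at the concentration tested, a lower number a stronger effect), compound 1 gives 98%, while compound 2 gives 32%. Within the data shown here, the only measured step, a number 66 percentage points lower from compound 1 to compound 2 (beyond the scatter), is a large drop. On the two numbers shown, compound 2 stands lowest, with compound 1 the nearest and above it by that step.

Compound 3 `CCCCCCc1ccc(NC(=O)N[C@H](C)c2ccccc2)cc1` continues the same chain of compound 2: ethyl in place of hydrogen on a saturated chain carbon, four bonds along the chain from an aromatic carbon. Among the measured compounds shown here, the one step that bears on this is a number 66 percentage points lower from compound 1 to compound 2 (beyond the scatter), which was large and downward for a lengthening of the same chain. For compound 3 a step in the same direction is expected, but smaller, because compound 2 already gives 32% and the read-out has little room left to fall; the read-out is a percentage and cannot go far below what compound 2 shows. Compound 3 is therefore estimated at 15%, with a range from 0% to 40%. This amounts to an expected step of a number 17 percentage points lower from compound 2 to compound 3 (beyond the scatter).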

Compound 3, a percentage reported as activity, at one concentration (the size of the read-out at that concentration, not a potency): 101%
For compound 3 the middle estimate is 86 percentage points below the measured one; measured number outside the range, above it.
By their numbers in this assay, from the lowest: compound 2; then compounds 1 and 3 (each within the scatter of the next).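

Ethyl in place of hydrogen on a saturated chain carbon, four bonds along the chain from an aromatic carbon, reverses the direction seen earlier: in this assay the step is a number 69 percentage points higher from compound 2 to compound 3 (beyond the scatter), so further lengthening at this place does not extend the earlier fall. Measured against the shorter chain, the longer chain gives a number 3 percentage points higher from compound 1 to compound 3 (within the scatter), which leaves compound 2 as the only one of the three set apart from the others, and the read-out follows no single direction with chain length. Nothing measured here accounts for this reversal.

Open is how narrow the effect is along the chain, since only three chains are shown and methyl in place of hydrogen at the same place on compound 2 would show whether a slightly longer chain stays with compound 2 or goes with compound 3. Also open, from the compounds shown here alone, is whether a longer chain, or a chain of similar reach ending in an amine or a carboxylic acid, would restore the low number of compound 2 at 32%.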